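The source may hold more compounds than are shown below. What is called first, only, known or untested is meant among the compounds shown, and "the series" means these compounds.

Going by the values given here, compound 2 `COC(=O)[C@H](Cc1cccc(C(=N)N)c1)[C@@H](C)NC(=O)c1ccc(-c2cccc(C(N)=O)c2)cc1` is the one compound here with a measured number: in an assay on isolated protein for inhibition of serine protease 1 (Homo sapiens) (on this read-out lower numbers stand for stronger inhibition and higher numbers for weaker inhibition), compound 2 gives 90 nM. Its partner compound 1 `CCOC(=O)NCc1cccc(-c2ccc(C(=O)N[C@H](C)[C@@H](Cc3cccc(C(=N)N)c3)C(=O)OC)cc2)c1` reached only a limit of the assay, since in this assay compound 1 gives > 2900 nM. Among the compounds with values here, the step from one to the other was an at least 32-fold lower number from compound 1 to compound 2 (1.50 log units; beyond the scatter), with carbamoyl in place of ((ethoxycarbonyl)amino)methyl on an aromatic carbon; that is the only measured step, and it is anchored at the limit of > 2900 nM in this assay, at which 1 of the 2 values shown sits, so its true size is unknown beyond its lower bound.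

Compound 3 `COC(=O)[C@H](Cc1cccc(C(=N)N)c1)[C@@H](C)NC(=O)c1ccc(-c2ccc(C(N)=O)cc2)cc1` keeps every atom of compound 2 and changes only where the carbamoyl sits: 4-carbamoylphenyl in place of 3-carbamoylphenyl on an aromatic carbon. Within the data shown here, no measured step concerns such a move of a group around a ring, so the single large step above offers no direct guide, and with the same atoms present a modest step is the natural expectation. The step from compound 2 to compound 3 is expected to be a 1.8-fold higher number from compound 2 to compound 3 (0.25 log units; within the scatter). Compound 3 is therefore estimated to give 160 nM in this assay, with a plausible range from 40 nM to 700 nM.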

Compound 3, inhibition constant: 42 nM
Compound 3: the middle estimate sits 3.8-fold (0.58 log units) above what was measured, and the stated range covers the measured number.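

Position alone matters on this ring: a 2.1-fold lower number from compound 2 to compound 3 (0.33 log units; beyond the scatter) in this assay, with 4-carbamoylphenyl replacing 3-carbamoylphenyl. The earlier step exchanged one group for a different one, so it could not separate the presence of the carbamoyl from its placement; here the group entering and the group leaving have the same atoms and the same counts of hydrogen-bond donors and acceptors, and only the placement differs, with the carbamoyl now para to a large group. Going by these compounds, this modest step is a smaller lever than the exchange of groups, which was large, but the true size of that earlier step remains unknown, and compound 1 marks a limit of the assay rather than a number: the limit of > 2900 nM in this assay, at which 1 of the 3 values shown sits.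

Nothing shown bears on why moving the carbamoyl lowers the number. On these data alone, it also remains open whether another group in that same place, such as a carboxylic acid, a nitrile or an amine, would match the carbamoyl of compound 3, and whether the ((ethoxycarbonyl)amino)methyl group of compound 1 would fare any better there.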